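Swapping the benzyl group under a solubility limit

The source may report more compounds than this note shows. Statements on the series, on what has been measured and on what is new or still open speak of the compounds shown alone.

In a physicochemical assay for solubility (a higher number here means a more soluble compound, a lower number a less soluble compound), compound 1 (`O=C(O)c1ccc(C(=O)/C(=C\c2ccc(Cl)c([N+](=O)[O-])c2)SCc2ccc(F)cc2)cc1`) gives < 1000 ug/mL as a limit of the assay and not a number. Compound 2 (`O=C(O)c1ccc(C(=O)/C(=C\c2ccc(F)c([N+](=O)[O-])c2)SCc2ccc(F)cc2)cc1`) gives < 1000 ug/mL which is also a limit. Compound 3 (`O=C(O)c1ccc(C(=O)/C(=C\c2ccc(Br)c([N+](=O)[O-])c2)SCc2ccc(F)cc2)cc1`) gives < 1000 ug/mL which is a limit as well. Compound 1 therefore has no exact place on the scale, and the series stands at the limit of < 1000 ug/mL in this assay, at which 3 of the 3 values shown sit, with no number yet.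

Compound 4 (`O=C(O)c1ccc(C(=O)/C(=C\c2ccc(Cl)c([N+](=O)[O-])c2)SCc2ccc(Cl)cc2Cl)cc1`) differs from compound 1 in one place, with 2,4-dichlorophenyl in place of 4-fluorophenyl on a saturated chain carbon bound to a sulfur. Three measured steps could serve as a guide. Fluoro in place of chloro on an aromatic carbon gives a step that the two limits leave unreadable from compound 1 to compound 2 and bromo in place of chloro gives a step that the two limits leave unreadable from compound 1 to compound 3 while bromo in place of fluoro gives a step that the two limits leave unreadable from compound 2 to compound 3 in the same way. None of them has a readable size, and none touches the place that changes in compound 4.

No direction can be foreseen, so the expected change is a step that the limit leaves unreadable from compound 1 to compound 4 as a rough estimate only. Compound 4 is estimated at 300 ug/mL with an expected range of 30 ug/mL to 1000 ug/mL. A limit in place of a number is also to be expected for compound 4.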

Compound 4, solubility: < 1000 ug/mL
Compound 4: no number, only a limit; the forecaster's own chance of this, stated with the estimate: 90%; the middle value lies beyond the limit too.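

Compound 1 and compound 4 each carry only a limit and not a number, so the step between them cannot be read, and the series stays where it stood: the limit of < 1000 ug/mL in this assay, at which 4 of the 4 values shown sit.

The compounds shown leave open where any of them stands on the scale of this assay, and whether 2,4-dichlorophenyl in place of 4-fluorophenyl shifts that place at all, or in which direction.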